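The source may report more compounds than this note shows. Statements on the series, on what has been measured and on what is new or still open speak of the compounds shown alone.

Measured compounds in a functional assay on the whole organism for antagonist activity, with Rattus norvegicus as the target; a higher number here means that more compound is needed for the effect, a lower number that less compound is needed:

Compound 1 `Clc1cccc2c1CC2CCCN1CCN(c2cccc3c2OCCO3)CC1` gives 3.09 mg/kg.
Compound 2 `c1ccc2c(c1)CC2CCN1CCN(c2cccc3c2OCCCO3)CC1` gives 2.68 mg/kg.
Compound 3 `C1=C(CCN2CCN(c3cccc4c3OCCO4)CC2)c2ccccc2C1` gives 0.45 mg/kg.

Among these three numbers compound 2 stands second highest. Its nearest neighbour is compound 1, whose value is within the scatter of compound 2, so the two cannot be told apart on this evidence. Compound 3 lies furthest away, with a lower number that is beyond the scatter.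

Compound 4 `c1ccc2c(c1)CC2CN1CCN(c2cccc3c2OCCCO3)CC1` has not yet been measured in this assay. It differs from compound 2 in one place: a group of 8 heavy atoms (8 carbon; one four-membered non-aromatic ring of carbon only, one six-membered aromatic ring of carbon only) in place of a group of 9 heavy atoms (9 carbon; one four-membered non-aromatic ring of carbon only, one six-membered aromatic ring of carbon only), on a saturated chain carbon bound to an amine nitrogen in a ring. For the measured compounds named here, no pair of measured compounds shows the effect of this particular change, so there is no step in this assay to lean on.

Given the absence of a guiding step, only a modest shift is expected, and its direction is uncertain; the estimated step of a 1.3-fold higher number from compound 2 to compound 4 (0.12 log units; within the scatter) is taken to be small and slightly towards a higher number. For compound 4 the expected value in this assay is 3.5 mg/kg, with a range from 1 mg/kg to 12 mg/kg.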

Compound 4, dose for 50% inhibition: 0.32 mg/kg
Compound 4: middle estimate off by 11-fold (1.04 log units), on the high side; the whole stated range lies above it.
By their numbers in this assay, from the lowest: compounds 4 and 3 (each within the scatter of the next); then compounds 2 and 1 (each within the scatter of the next).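

In this assay the group of 8 heavy atoms, in place of the group of 9 heavy atoms on a saturated chain carbon bound to an amine nitrogen in a ring, gives an 8.4-fold lower number from compound 2 to compound 4 (0.92 log units; beyond the scatter) and this step lies beyond the usual scatter. The earlier compounds shown here offered no pair differing in one place, whereas this pair shows that the position responds clearly to a small change, even though both groups carry the same two rings and no hydrogen-bond donors or acceptors. Nothing measured here bears on the reason for this step.

Still open, going by these compounds, is how a longer chain at this position would compare, since one step gives no trend. Also open, on these data alone, is whether a methoxy group on the six-membered aromatic ring would keep the lower dose of compound 4.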